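This account rests on a few compounds, and the source may have more. Where it says the series, first, only, none or still open, it means among the compounds named here.

Working notes on a set of sulfonamides that share the core of compound 1, `Cc1cc(C)c(S(=O)(=O)N2CCC(N3CCC(C)CC3)CC2)c(C)c1`, and vary in the group attached to the sulfonyl sulfur. The series is followed in an ADME assay on HCT-116 cells (Homo sapiens) for cytotoxicity, read by CellTiter-Glo, with a stated time of 72 h; a higher number here means a weaker inhibitor, a lower number a stronger inhibitor. Compound 1 gives > 5000 nM, which is a limit of the assay and not a number. Compound 2, `CC1CCN(C2CCN(S(=O)(=O)c3cccnc3Cl)CC2)CC1`, gives > 10000 nM, again a limit rather than a number. Compound 3, `CC1CCN(C2CCN(S(=O)(=O)c3cccc(-c4ccc(F)cc4)c3)CC2)CC1`, gives > 5000 nM, also a limit. Compound 2 therefore stands on a limit, and the two further values shown are limits as well: of the three values, one sits at the limit of > 10000 nM in this assay, at which 1 of the 3 values shown sits, and two sit at the limit of > 5000 nM in this assay, at which 2 of the 3 values shown sit.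

Among the compounds with values here, no step between measured compounds can be read, since none of the measured pairs differ in one place and none of the values is a number. The untested compound 4, `CC1CCN(C2CCN(S(=O)(=O)c3ccc(Cl)c(Cl)c3)CC2)CC1`, differs from compound 2 by 3,4-dichlorophenyl in place of 2-chloropyridin-3-yl on a sulfonyl sulfur. With every measured value a limit, no direction for this change can be drawn from the compounds shown; the expected step in this assay is none beyond the scatter, and the estimated step of an at least 1.2-fold lower number from compound 2 to compound 4 (0.09 log units; that floor lies within the scatter) expresses exactly that. Compound 4 is expected to give 8000 nM, within a range from 3000 nM to 20000 nM, and most probably the assay will again report only a limit.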

Compound 4, half-maximal inhibitory concentration: > 5000 nM
Compound 4: a limit, no number; the forecaster's own chance of this, stated with the estimate: 80%; the middle value does not contradict the limit.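

In this assay compound 4 gives > 5000 nM, a limit and not a number. Compound 2 gives > 10000 nM, also a limit, so no step can be read from compound 2 to compound 4. The compounds shown leave open whether 3,4-dichlorophenyl in place of 2-chloropyridin-3-yl on a sulfonyl sulfur changes the read-out in this assay at all, and in which direction.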